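This account rests on a few compounds, and the source may have more. Where it says the series, first, only, none or still open, it means among the compounds named here.

Working notes on the series, read in an ADME assay on HEK-293T cells (Homo sapiens) for cytotoxicity, read by MTT assay, with a stated time of 3 days; on this read-out higher numbers stand for lower toxicity in this test and lower numbers for higher toxicity in this test. Compound 1 `CC(C)OC(=O)COC(=O)c1ccc([N+](=O)[O-])o1` gives > 100000 nM, which is a limit of the assay. Compound 2 `O=C(COC(=O)c1ccc([N+](=O)[O-])o1)NCC1CCCO1` gives > 100000 nM, again a limit. Within the data shown here, compound 3 `CC(C)(C)N(Cc1cccc([N+](=O)[O-])c1)C(=O)COC(=O)c1ccc([N+](=O)[O-])o1` gives 78000 nM, the only actual number in this assay so far.

The next compound is compound 4 `CC(C)(C)N(Cc1ccc(F)cc1)C(=O)COC(=O)c1ccc([N+](=O)[O-])o1`, which differs from compound 3 on a saturated chain carbon bound to an amide-type nitrogen: 4-fluorophenyl in place of 3-nitrophenyl on a saturated chain carbon bound to an amide-type nitrogen. Among the measured compounds shown here, the only measured step is a step that the two limits leave unreadable from compound 1 to compound 2. That step lies on a carbonyl carbon, at another place in the structure, and gives no size to carry over to this change. For the measured compounds named here, no measured step covers the exchange of these two aryl groups. No step beyond the usual scatter is therefore expected in this assay, and the expectation rests on compound 3 at 78000 nM. The estimated change is a 1.0-fold higher number from compound 3 to compound 4 (0.01 log units; within the scatter). For compound 4 the expected value is 80000 nM. The estimated range for compound 4 runs from 35000 nM to 170000 nM.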

Compound 4, half-maximal cytotoxic concentration: > 100000 nM
Compound 4 ended at the assay's limit (the forecaster's own chance of this, stated with the estimate: 35%); middle value at least 1.2-fold (0.09 log units) from the limit.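

In this assay, among these compounds, the exchange on a saturated chain carbon bound to an amide-type nitrogen gives an at least 1.2-fold higher number from compound 3 to compound 4 (0.10 log units; that floor lies within the scatter), the first step with a readable floor. Compound 4 gives > 100000 nM, which is a limit of the assay. The floor of this step does not separate 4-fluorophenyl from 3-nitrophenyl beyond the scatter, and most of the series now rests at one end of the read-out: the limit of > 100000 nM in this assay, at which 3 of the 4 values shown sit.

Still open, going by these compounds, is the true size of this step, and whether the number of compound 3 goes with the nitro group on its phenyl ring. Also open, on these data alone, is what a plain phenyl, or a phenyl carrying an amine or a carboxylic acid, gives at this place.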